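Hydroquinone to quinone on a pyrazole-bearing core

A few compounds are considered here, and "the series" means these few. Any claim that something is new, unique, unknown or untested is made for them only; others in the source may bear on it.

Compound 1, `Oc1ccc(O)c(-c2cc(-c3ccccc3)nn2-c2ccccc2)c1`: 75700 nM in a functional assay on cells (Cancer cell lines, Homo sapiens) for cytotoxicity, read by sulforhodamine B assay, with a stated time of 48 h; a lower number here means a stronger inhibitor of growth, a higher number a weaker inhibitor of growth
Compound 2, `Oc1ccc(O)c(-c2cc(-c3ccc(Cl)cc3)nn2-c2ccccc2)c1`: 41100 nM

Among the compounds with values here, on the two numbers so far, compound 2 gives the lowest number in this assay, with compound 1 nearest at a 1.8-fold lower number from compound 1 to compound 2 (0.27 log units; within the scatter). Compound 3, `O=C1C=CC(=O)C(c2cc(-c3ccc(Cl)cc3)nn2-c2ccccc2)=C1`, differs from compound 2 in a group of 8 heavy atoms (6 carbon, 2 oxygen; one six-membered non-aromatic ring of carbon only) in place of a group of 8 heavy atoms (6 carbon, 2 oxygen; one six-membered aromatic ring of carbon only), on an aromatic carbon. Within the data shown here, the one measured step, a 1.8-fold lower number from compound 1 to compound 2 (0.27 log units; within the scatter), concerns a chloro group and does not bear on this exchange; no measured pair shows the effect of the 2,5-dihydroxyphenyl group giving way to the entering ring. The step is therefore expected to be a 2.1-fold lower number from compound 2 to compound 3 (0.31 log units; beyond the scatter), with wide uncertainty. Compound 3 is estimated at 20000 nM, in the range 5000 nM to 80000 nM.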

Compound 3, concentration for total growth inhibition: 69300 nM
Compound 3: the middle estimate sits 3.5-fold (0.54 log units) below what was measured; measured number inside the range.
By their numbers in this assay, from the lowest: compounds 2, 3 and 1 (each within the scatter of the next).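

Exchanging the 2,5-dihydroxyphenyl group on this aromatic carbon for the entering non-aromatic ring, which has no hydrogen-bond donors, gives a 1.7-fold higher number from compound 2 to compound 3 (0.23 log units; within the scatter) in this assay and so produces no readable change. This position therefore accepts the exchange without a shift beyond the scatter, even with the hydrogen-bond donors of the leaving group gone. No measurement at hand speaks to the reason for this result. The compounds shown leave open whether an amine, a methoxy group or a carboxylic acid on this aromatic carbon would move the number beyond the scatter. Going by these compounds, whether the entering ring gives the same result without the 4-chlorophenyl group of compound 3 also stays open.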